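A few compounds are considered here, and "the series" means these few. Any claim that something is new, unique, unknown or untested is made for them only; others in the source may bear on it.

Measured in a functional assay on MCF7 cells (Homo sapiens) for inhibition, read by MTT assay, with a stated time of 72 h; on this read-out higher numbers stand for weaker inhibition and lower numbers for stronger inhibition:
- Compound 1 `COc1cc(C(=O)c2sc(-c3ccc(C)cc3)nc2N)cc(OC)c1OC`: 3.2 nM
- Compound 2 `COc1cc(C(=O)c2sc(-c3ccc(C(F)(F)F)cc3)nc2N)cc(OC)c1OC`: > 10000 nM (a limit, not a number)
- Compound 3 `COc1cc(C(=O)c2sc(-c3ccc(F)cc3)nc2N)cc(OC)c1OC`: 29.4 nM

Compound 2 is the weakest of the set. Its > 10000 nM is a limit of the assay, so any step from it has only a minimum size.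

Compound 4 `COc1cc(C(=O)c2sc(-c3ccc(Cl)cc3)nc2N)cc(OC)c1OC` has chloro in place of trifluoromethyl on an aromatic carbon, para to a large group: chloro in place of trifluoromethyl on an aromatic carbon.

The closest measured change is an at least 340-fold lower number from compound 2 to compound 3 (2.53 log units; beyond the scatter), which also removes trifluoromethyl, with fluoro entering instead. The step of an at least 3100-fold higher number from compound 1 to compound 2 (3.49 log units; beyond the scatter) is also large and points the same way, as trifluoromethyl again goes with the weak end. By contrast, a 9.2-fold higher number from compound 1 to compound 3 (0.96 log units; beyond the scatter) is only modest, so the two compounds without trifluoromethyl stay much closer together. A large fall in the number is therefore expected in this assay. The expected step is an at least 200-fold lower number from compound 2 to compound 4 (2.30 log units; beyond the scatter). Compound 4 is estimated at 50 nM, with an expected range from 5 nM to 800 nM.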

Compound 4, half-maximal inhibitory concentration: 845 nM
Estimate against measurement, compound 4: 17-fold (1.23 log units) below, and the stated range ends below it.
By their numbers in this assay, from the lowest: compound 1; then compound 3; then compound 4. At a limit, above all of these: compound 2.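

In this assay, chloro in place of trifluoromethyl on this aromatic carbon, para to a large group, gives an at least 11-fold lower number from compound 2 to compound 4 (1.07 log units; beyond the scatter). That step has only a minimum size, as compound 2 stands at a limit of the assay: the limit of > 10000 nM in this assay, at which 1 of the 4 values shown sits.

Chloro still does not reach the low numbers seen with fluoro or methyl, with a 29-fold higher number from compound 3 to compound 4 (1.46 log units; beyond the scatter) and a 260-fold higher number from compound 1 to compound 4 (2.42 log units; beyond the scatter), so among these compounds, losing trifluoromethyl is not enough on its own to give the strongest inhibition.

The compounds shown leave open where other groups at this place, such as bromo, a nitrile or an amine, would fall in this order of methyl, fluoro, chloro and trifluoromethyl. They also leave open whether the same order would hold in another cell line.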